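This account rests on a few compounds, and the source may have more. Where it says the series, first, only, none or still open, it means among the compounds named here.

Measured compounds in a functional assay on Huh-7 cells (Homo sapiens) for inhibition, read by sulforhodamine B assay, with a stated time of 72 h; a higher number here means a weaker inhibitor, a lower number a stronger inhibitor:

compound 1 `O=C(/C=C/c1cn(-c2ccccc2)nc1-c1cccnc1)c1ccccc1` — 2300 nM
compound 2 `COc1cc(C(=O)/C=C/c2cn(-c3ccccc3)nc2-c2cccnc2)cc(OC)c1OC` — 1900 nM
compound 3 `O=C(/C=C/c1cn(-c2ccccc2)nc1-c1ccncc1)c1ccccc1` — 1800 nM

Compound 3 differs from compound 1 by pyridin-4-yl in place of pyridin-3-yl on an aromatic carbon. The three values sit close together: compound 2 against compound 3 and against compound 1 shows only gaps within the scatter, so no order can be read among them. The difference between the core of compound 1 and the core of compound 2 is not broken down here.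

The unmeasured compound 4 `COc1cc(C(=O)/C=C/c2cn(-c3ccccc3)nc2-c2ccncc2)cc(OC)c1OC` differs from compound 2 by pyridin-4-yl in place of pyridin-3-yl on an aromatic carbon. The place lines of the two changes agree word for word, so this is the same change as the one already measured, where the step is a 1.3-fold lower number from compound 1 to compound 3 (0.11 log units; within the scatter). The step expected from compound 2 to compound 4 is a 1.2-fold lower number from compound 2 to compound 4 (0.07 log units; within the scatter), and this rests on the measured pair because the data show a 1.3-fold lower number from compound 1 to compound 3 (0.11 log units; within the scatter). Compound 4 is therefore estimated at 1600 nM in this assay. The estimated range for compound 4 runs from 800 nM to 3200 nM.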

Compound 4, half-maximal inhibitory concentration: 3500 nM
Compound 4: the middle estimate sits 2.2-fold (0.34 log units) below what was measured; measured number above the stated range.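

Swapping pyridin-3-yl for pyridin-4-yl on the second core gives a 1.8-fold higher number from compound 2 to compound 4 (0.27 log units; within the scatter) in this assay. Set beside the same swap on the core of compound 1, the step shows no difference between the two cores that can be told from scatter: the same change on two cores in this assay, a 1.3-fold lower number (0.11 log units; within the scatter) from compound 1 to compound 3 and a 1.8-fold higher number (0.27 log units; within the scatter) from compound 2 to compound 4, 2.4-fold (0.37 log units) apart, within the scatter of two such steps

So, on these two cores, the swap gives no step beyond the scatter and no sign that the core alters its size, but this rests on only two pairs and does not show that the two cores respond identically or that other cores would behave the same way.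

The compounds shown leave open whether any change in this series can move the number beyond the scatter. Pyridin-2-yl in the same place, and an amine or a carboxylic acid on the phenyl group or in its place, would test this on the shared core.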